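Taking the propanoyl group off compound 1

This account rests on a few compounds, and the source may have more. Where it says the series, first, only, none or still open, it means among the compounds named here.

Of the compounds shown here, three have been measured so far in a functional assay on MCF7 cells (Homo sapiens) for inhibition, read by MTT assay, with a stated time of 72 h; a lower number here means a stronger inhibitor, a higher number a weaker inhibitor. Compound 1 (`CCC(=O)O[C@@H](/C(C)=C/[C@@H](C)c1oc(CC)c(C)c(=O)c1C)[C@H](C)[C@@H](OC(=O)CC(C)C)[C@@H](C)c1oc([C@@H](C)[C@@H](O)CC)c(C)c(=O)c1C`) gives 12000 nM as the lowest number of the three. Compound 2 (`CCc1oc([C@H](C)/C=C(\C)[C@H](OC(C)=O)[C@H](C)[C@@H](OC(=O)CC(C)C)[C@@H](C)c2oc([C@@H](C)[C@H](CC)OC(C)=O)c(C)c(=O)c2C)c(C)c(=O)c1C`) gives 25000 nM as the nearest number to it, and compound 3 (`CCC(=O)[C@@H](C)c1oc([C@H](C)[C@@H]2O[C@](O)([C@@H](C)c3oc(CC)c(C)c(=O)c3C)[C@@H](C)[C@@H](O)[C@@H]2C)c(C)c(=O)c1C`) gives 87000 nM as the furthest. Both gaps from compound 1 lie beyond the scatter, so compound 1 is the strongest inhibitor of this small set.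

Compound 4 (`CCc1oc([C@H](C)/C=C(\C)[C@H](O)[C@H](C)[C@@H](OC(=O)CC(C)C)[C@@H](C)c2oc([C@@H](C)[C@@H](O)CC)c(C)c(=O)c2C)c(C)c(=O)c1C`) has not yet been measured. It differs from compound 1 in one place (hydrogen in place of propanoyl on an oxygen on a saturated carbon): hydrogen in place of propanoyl on an oxygen on a saturated carbon, which reads as propanoyloxy to hydroxy. Among the measured compounds shown here, no pair of measured compounds shows this change, so the data give no direct size for it. The expectation rests on the spread of the series instead. Compound 1 at 12000 nM sits at its low end, so there is more room for a move upward, and compound 2 at 25000 nM marks the nearest neighbouring number. The expected change is a 2.2-fold higher number from compound 1 to compound 4 (0.34 log units; beyond the scatter) as a modest estimated move toward weaker inhibition. For compound 4 the estimated value is 26000 nM (expected range 9000 nM to 70000 nM)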

Compound 4, half-maximal inhibitory concentration: > 100000 nM
Compound 4 was reported as a limit; the forecaster's own chance of this, stated with the estimate: 15%; middle value at least 3.8-fold (0.58 log units) from the limit.
By their numbers in this assay, from the lowest: compound 1; then compound 2; then compound 3. At a limit, above all of these: compound 4.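

In this assay, among the compounds shown here, the change from propanoyloxy to hydroxy on a saturated carbon is the first change in a single place that can be read, and it gives an at least 8.3-fold higher number from compound 1 to compound 4 (0.92 log units; beyond the scatter). Compound 4 is reported only as a limit, > 100000 nM. The step therefore shows that this position is not indifferent to what sits on its oxygen, and that the propanoyl group goes with the measurable inhibition of compound 1, though the full size of the step cannot be read because the value of compound 4 is only a limit: the limit of > 100000 nM in this assay, at which 1 of the 4 values shown sits.

What the compounds shown leave open is whether the propanoyl group itself matters or whether another group on this oxygen, such as a butanoyl group or a simple methyl ether, would keep the same level of inhibition. For the compounds shown here, they also leave open whether the isolated hydroxy group on the other side of the chain, the one compound 1 and compound 4 share, would respond in the same way to a single change of its own.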